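Swapping the aryl group on an inactive compound

A few compounds are considered here, and "the series" means these few. Any claim that something is new, unique, unknown or untested is made for them only; others in the source may bear on it.

So far, two related compounds have been tested in a functional assay on PC-3 cells (Homo sapiens) for cytotoxicity, read by MTT assay, with a stated time of 72 h; a lower number here means a stronger inhibitor, a higher number a weaker inhibitor. There, compound 1 (`O=C(N/N=C/c1cccc(Br)c1)Nc1cc2c(Nc3ccc(F)c(Cl)c3)ncnc2cc1O[C@H]1CCOC1`) gives 15500 nM as its half-maximal inhibitory concentration. Compound 2 (`COc1cc2ncnc(Nc3ccc(F)c(Cl)c3)c2cc1NC(=O)N/N=C/c1cccc(Br)c1`) has no number: it is recorded as "not active" (no number reported) and can be placed only by that description. Compound 3 (`COc1cc2ncnc(Nc3ccc(F)c(Cl)c3)c2cc1NC(=O)N/N=C/c1ccc(F)cc1Cl`) differs from compound 2 in one place: 2-chloro-4-fluorophenyl in place of 3-bromophenyl on a carbon with a double bond to nitrogen puts 2-chloro-4-fluorophenyl in place of 3-bromophenyl on a carbon with a double bond to nitrogen. Going by the values given here, no measured step shows what such a swap does. A large gain in this assay is therefore not expected, only a small step at most towards measurable but weak inhibition, and a report without a number remains quite possible. For compound 3 the estimated value is 30000 nM with an expected range (10000 nM to 90000 nM).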

Compound 3, half-maximal inhibitory concentration: 25700 nM
The estimate for compound 3 lay 1.2-fold (0.07 log units) above the measured number; the range from low to high includes it.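

Going by these compounds alone, compound 2 is recorded only as "not active", so although compound 3 gives 25700 nM in this assay no step between them can be read. The compounds shown leave open how much the 2-chloro-4-fluorophenyl group itself contributes to that value. Nothing shown bears on the reason for this result.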